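Aryl urea variation on the aminopyrimidine-pyrrolidine series

The source may hold more compounds than are shown below. What is called first, only, known or untested is meant among the compounds shown, and "the series" means these compounds.

Three ureas sharing one core have been measured in an assay on a protein complex for displacement of a labelled ligand from CDK8/Cyclin C (Homo sapiens), read by TR-FRET, with a stated time of 1 h; a lower number here means a stronger inhibitor, a higher number a weaker inhibitor. Compound 1 `CNc1nccc(N2CC[C@H](NC(=O)Nc3cc(OC)cc(OC)c3)C2)n1` gives 5010 nM in this assay. Compound 2 `CNc1nccc(N2CC[C@H](NC(=O)Nc3cccc(C#N)c3)C2)n1` gives 3480 nM in this assay. Compound 3 `CNc1nccc(N2CC[C@H](NC(=O)Nc3ccc(C)c(Cl)c3)C2)n1` gives 18.4 nM in this assay, the lowest of the three numbers; the nearest is compound 2 and the furthest compound 1, both beyond the scatter.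

For the measured compounds named here, the one step between measured compounds that changes only the aryl group is a 190-fold lower number from compound 2 to compound 3 (2.28 log units; beyond the scatter), a large step.

Compound 4 `CNc1nccc(N2CC[C@H](NC(=O)Nc3cccc(OC)c3)C2)n1` is not yet measured. It differs from compound 3 in one place: 3-methoxyphenyl in place of 3-chloro-4-methylphenyl on an amide-type nitrogen. Going by the values given here, no measured pair shows exactly this exchange. Compound 1 carries two methoxy groups on the aryl ring and sits near compound 2 in this assay, both far above compound 3. Both measured aryl groups without the chloro-methyl pattern therefore give high numbers, and a single methoxy group is expected to behave closer to those than to compound 3, though the data cannot fix where between them.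

Compound 4 is thus expected to lose activity, with an estimated step of an 82-fold higher number from compound 3 to compound 4 (1.91 log units; beyond the scatter) in this assay. The estimate for compound 4 in this assay is 1500 nM, with a range from 300 nM to 6000 nM.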

Compound 4, half-maximal inhibitory concentration in the CDK8/Cyclin C assay: 3620 nM
Estimate against measurement, compound 4: 2.4-fold (0.38 log units) below, within the range that was stated.
By their numbers in the CDK8/Cyclin C assay, from the lowest: compound 3; then compounds 2, 4 and 1 (each within the scatter of the next).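

In the CDK8/Cyclin C assay compound 3 gives 18.4 nM and compound 4 gives 3620 nM, and the exchange on this amide-type nitrogen gives a 200-fold higher number from compound 3 to compound 4 (2.29 log units; beyond the scatter) and so puts a direct single-step size on leaving 3-chloro-4-methylphenyl for 3-methoxyphenyl. In the CDK8/Cyclin C assay the two other exchanges give a 1.0-fold higher number from compound 2 to compound 4 (0.02 log units; within the scatter) and a 1.4-fold lower number from compound 1 to compound 4 (0.14 log units; within the scatter) and show that methoxy in place of cyano and hydrogen in place of methoxy do not separate these compounds, which leaves compound 3 alone apart from compounds 1, 2 and 4. Against this, in a physicochemical assay for solubility, measured as kinetic solubility (a lower number here means a less soluble compound, a higher number a more soluble compound), compound 3 gives 72700 nM and compound 4 gives 116000 nM, which is only a 1.6-fold higher number from compound 3 to compound 4 (0.20 log units; within the scatter) for the same exchange and so does not follow the large step seen in binding.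

Open, as far as these compounds go, is whether the chloro or the methyl alone holds the low number, and how an aryl group bearing a trifluoromethyl, an amine or a carboxylic acid would read in the CDK8/Cyclin C assay alongside compound 3. Nothing shown bears on the cause of the large step.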